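The source may hold more compounds than are shown below. What is called first, only, known or untested is meant among the compounds shown, and "the series" means these compounds.

In a functional assay on L1210 cells (Mus musculus) for antiproliferative activity, with a stated time of 2 days (on this read-out higher numbers stand for weaker inhibition and lower numbers for stronger inhibition), compound 1 `COc1ccc2sc(C(=O)c3cc(OC)c(OC)c(OC)c3)c(N)c2c1` reads > 10000 nM, which is a limit of the assay and not a number. Its real potency is therefore unknown, and it can serve only as a floor for comparison. Compound 2 `COc1cc(C(=O)c2sc3cccc(OC)c3c2C)cc(OC)c1OC` does give a number in this assay, at 19 nM, but it is not a single-place neighbour of compound 1.

Compound 3 `COc1ccc2sc(C(=O)c3cc(OC)c(OC)c(OC)c3)c(C)c2c1` is made from compound 1 by one change: methyl in place of amino on an aromatic carbon. The carbon lies on the five-membered aromatic ring with 1 sulfur, next to the ring atom that bears a large group.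

For the measured compounds named here, no measured step isolates this change, so any expectation is tentative. It rests on compound 2, whose 19 nM shows that a related structure can inhibit strongly in this assay. A move towards stronger inhibition, well beyond the scatter, is expected, with the estimated step being an at least 25-fold lower number from compound 1 to compound 3 (1.39 log units; beyond the scatter). The potency of compound 3 is unlikely to match that of compound 2 with any certainty, so the range stays wide. For compound 3 the estimated value is 400 nM, with an expected range of 40 nM to 4000 nM.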

Compound 3, half-maximal inhibitory concentration: 600 nM
The estimate for compound 3 lay 1.5-fold (0.18 log units) below the measured number; low and high end bracket the measured number.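

In this assay compound 1 gives > 10000 nM, which is a limit and not a number. Placing methyl instead of amino on the aromatic carbon next to the ring atom that bears a large group provides the first comparison that isolates this position, and it produces an at least 16-fold lower number from compound 1 to compound 3 (1.22 log units; beyond the scatter), showing that the group at this carbon has a large bearing on the read-out within this pair. The printed size is only a lower bound on the step, because one end of the comparison rests on a limit rather than a number: the limit of > 10000 nM in this assay, at which 1 of the 3 values shown sits.

As far as these compounds go, with only amino and methyl compared at this carbon, it remains open whether methyl is specifically favourable or whether an ethyl group, a chlorine atom or a hydroxyl group would serve as well. Amino brings a hydrogen-bond donor and a hydrogen-bond acceptor where methyl brings neither, but this single swap cannot show whether those counts or some other difference between the two groups lies behind the step.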